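Notes on the step from compound 3 to compound 4

The source may hold more compounds than are shown below. What is called first, only, known or untested is meant among the compounds shown, and "the series" means these compounds.

Measured in a functional assay on K562 cells (Homo sapiens) for antiproliferative activity, with a stated time of 48 h; on this read-out lower numbers stand for stronger inhibition and higher numbers for weaker inhibition:
compound 1 `Cc1cc(=O)c2c(OCC3CO3)cc(OCC3CO3)cc2o1`: 6300 nM
compound 2 `Cc1cc(=O)c2c(OC[C@H]3CO3)cc(OC[C@H]3CO3)cc2o1`: 7860 nM
compound 3 `Cc1cc(=O)c2c(O)cc(OC[C@@H]3CO3)cc2o1`: 8030 nM

On these numbers compound 3 at 8030 nM stands level with the other two, since its value lies within the scatter of both compound 1 and compound 2. The next compound, compound 4 `Cc1cc(=O)c2c(OC[C@@H]3CO3)cc(OC[C@@H]3CO3)cc2o1`, has not been measured. It differs from compound 3 by (oxiran-2-yl)methyl in place of hydrogen on an oxygen on an aromatic ring in that (oxiran-2-yl)methyl takes the place of hydrogen on an oxygen on an aromatic ring.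

Within the data shown here, no measured step covers this exchange directly. Among the measured compounds shown here, the one measured step, a 1.2-fold higher number from compound 1 to compound 2 (0.10 log units; within the scatter), goes with the fact that one of compounds 1 and 2 is drawn with a defined configuration and the other without, at the place where they differ and bears on configuration only. For the measured compounds named here, it does show that the only change measured so far stays within the scatter. The remaining guide is the narrow band of the values themselves, with compound 1 at 6300 nM and compound 3 at 8030 nM within the scatter of each other. No step beyond the scatter is therefore expected in this assay, in either direction. The estimate amounts to a 1.1-fold lower number from compound 3 to compound 4 (0.06 log units; within the scatter) as the expected step. Compound 4 is expected at 7000 nM with an estimated range from 3500 nM to 14000 nM in this read-out.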

Compound 4, half-maximal inhibitory concentration: 19500 nM
Beside the measured number, compound 4's estimate is 2.8-fold (0.44 log units) below it; the measured number lies above the stated range.
By their numbers in this assay, from the lowest: compounds 1, 2 and 3 (each within the scatter of the next); then compound 4.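

In this assay, among these compounds, the exchange at this oxygen on an aromatic ring gives the first step beyond the scatter, with (oxiran-2-yl)methyl in place of hydrogen: a 2.4-fold higher number from compound 3 to compound 4 (0.39 log units; beyond the scatter). The earlier configuration step stayed within the scatter, whereas the mirror-image pair gives a 2.5-fold higher number from compound 2 to compound 4 (0.39 log units; beyond the scatter), so drawn configuration at these two stereocentres does show in this read-out, and this step can be assigned to configuration alone: the fact that compounds 2 and 4 differ only in the configuration as drawn. A step of modest size also separates compound 4 from the compound drawn without configuration, a 3.1-fold higher number from compound 1 to compound 4 (0.49 log units; beyond the scatter), although this comparison is less clean than the mirror-image one: the fact that one of compounds 1 and 4 is drawn with a defined configuration and the other without, at the place where they differ.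

On these data alone, whether a methyl or a longer alkyl chain on the same oxygen would give a step like that of (oxiran-2-yl)methyl remains open, so the three-membered ring cannot yet be separated from substitution of the hydrogen as such. Also open, as far as these compounds go, is which of the two stereocentres of compound 4 carries the configuration effect, and whether the same pattern would hold for a series with an amine in place of the oxirane.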